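Swapping the benzyl ring on a dithiocarbamate amide

The source may report more compounds than this note shows. Statements on the series, on what has been measured and on what is new or still open speak of the compounds shown alone.

Three compounds share a trimethoxyphenyl amide core and were tested in a functional assay on KYSE-450 cells (Homo sapiens) for inhibition, read by CCK-8 assay, with a stated time of 48 h; a higher number here means a weaker inhibitor, a lower number a stronger inhibitor. Compound 1 `COc1ccc(CN(C(=O)CSc2nc3ccccc3o2)c2cc(OC)c(OC)c(OC)c2)cc1` gives 840 nM. Compound 2 `COc1cc(N(Cc2ccc(Cl)cc2)C(=O)CSC(=S)N2CCN(C(=O)OC(C)(C)C)CC2)cc(OC)c1OC` gives 11900 nM, and compound 3 `COc1cc(N(Cc2ccc(Br)cc2)C(=O)CSC(=S)N2CCN(C(=O)OC(C)(C)C)CC2)cc(OC)c1OC` gives 10700 nM. Compound 3 thus stands second highest of the three numbers: its nearest neighbour is compound 2, a gap within the scatter, while compound 1 is far lower in this assay, a gap well beyond the scatter. Within the data shown here, the one step between compounds differing in a single place, a 1.1-fold lower number from compound 2 to compound 3 (0.05 log units; within the scatter), shows that exchanging one halogen for another on the benzyl ring changed nothing detectable.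

Compound 4 `COc1ccc(CN(C(=O)CSC(=S)N2CCN(C(=O)OC(C)(C)C)CC2)c2cc(OC)c(OC)c(OC)c2)cc1F` differs from compound 3 as follows: 3-fluoro-4-methoxyphenyl in place of 4-bromophenyl on a saturated chain carbon bound to an amide-type nitrogen. Among the measured compounds shown here, compound 1 carries a methoxy-bearing benzyl ring too, but its acyl part also differs, so no single-place step connects it to compound 4. For the measured compounds named here, the only clean comparison, the halogen swap, was flat, so for compound 4 a modest change is expected, direction uncertain: a 1.3-fold lower number from compound 3 to compound 4 (0.13 log units; within the scatter). Compound 4 is estimated at 8000 nM, within 3000 nM to 20000 nM.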

Compound 4, half-maximal inhibitory concentration: 2410 nM
Beside the measured number, compound 4's estimate is 3.3-fold (0.52 log units) above it, and the stated range ends above it.
By their numbers in this assay, from the lowest: compound 1; then compound 4; then compounds 3 and 2 (each within the scatter of the next).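

The benzyl position is not indifferent after all. The chloro-to-bromo swap moved nothing detectable, yet the 3-fluoro-4-methoxyphenyl ring gives a 4.4-fold lower number from compound 3 to compound 4 (0.65 log units; beyond the scatter) and, against the chloro partner, a 4.9-fold lower number from compound 2 to compound 4 (0.69 log units; beyond the scatter), so a change on this saturated chain carbon bound to an amide-type nitrogen can yield a stronger inhibitor when more than the halogen is altered. Nothing measured here accounts for this gain.

Fluoro and methoxy enter together, so the compounds shown cannot separate what each contributes to the step. As far as these compounds go, how a benzyl ring carrying an amine or a carboxylic acid would behave at this place also stays open.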